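Tail flick series: carboxy side chain variant of compound 3

The compounds below may be only part of what the source reports. "The series", "measured", "known", "first", "only" and "open" are said of these compounds alone.

Measured compounds:
compound 1 `N=C(N)NCCC[C@H](NC(=O)CN(c1nc(Cl)nc2[nH]cnc12)C1CC1)C(=O)O` — 51%
compound 2 `O=C(CN(c1nc(Cl)nc2[nH]cnc12)C1CC1)N[C@@H](CO)C(=O)O` — 39.8%
compound 3 `NCCCC[C@H](NC(=O)CN(c1nc(Cl)nc2[nH]cnc12)C1CC1)C(=O)O` — 53.8%

In a functional assay on the whole organism (Tail, strain ICR) with Mus musculus as the target, in the tail flick test, with a stated time of 60 min, at a dose of 25 umol/kg by the oral route (on this read-out higher numbers stand for a stronger effect at the one dose given and lower numbers for a weaker effect), compound 3 gives the highest of the three numbers, but its gap to compound 1 is within the scatter, so the two cannot be ordered; only compound 2 stands clearly lower.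

Compound 4 `O=C(O)C[C@H](NC(=O)CN(c1nc(Cl)nc2[nH]cnc12)C1CC1)C(=O)O` is not yet measured. Its change from compound 3 is carboxy in place of 3-aminopropyl on a saturated chain carbon, two bonds along the chain from an amide-type nitrogen and a carbonyl carbon. Within the data shown here, the steps that bear on this position are a number 14 percentage points higher from compound 2 to compound 3 (beyond the scatter) and a number 11.2 percentage points lower from compound 1 to compound 2 (beyond the scatter), both modest and beyond the scatter, while a number 2.8 percentage points higher from compound 1 to compound 3 (within the scatter) is within the scatter. Compound 4 carries neither of the groups found in compound 1 or compound 3 at this place, so a modest drop is expected, about a number 13.8 percentage points lower from compound 3 to compound 4 (beyond the scatter). Compound 4 is estimated at 40%, range 26% to 54%.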

Compound 4, a percentage reported as activity, at one dose (the size of the read-out at that dose, not a potency): 38.9%
The estimate for compound 4 lay 1.1 percentage points above the measured number; measured number inside the range.
By their numbers in this assay, from the lowest: compounds 4 and 2 (each within the scatter of the next); then compounds 1 and 3 (each within the scatter of the next).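

In this assay, carboxy in place of hydroxy at this saturated chain carbon gives a number 0.9 percentage points lower from compound 2 to compound 4 (within the scatter), whereas a number 14.9 percentage points lower from compound 3 to compound 4 (beyond the scatter) and a number 12.1 percentage points lower from compound 1 to compound 4 (beyond the scatter). The four compounds therefore fall into two levels: the chains ending in nitrogen groups, in compound 1 and compound 3, stand above the hydroxy and carboxy variants, in compound 2 and compound 4, and none of the four goes against this split. No supporting data are available to explain this split.

Chain length and the terminal group still change together in this set. A plain butyl chain, a shorter 2-aminoethyl chain and a longer 2-carboxyethyl chain would each help to separate the two.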